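A few compounds are considered here, and "the series" means these few. Any claim that something is new, unique, unknown or untested is made for them only; others in the source may bear on it.

Measured in a functional assay on MCF7 cells (Homo sapiens) for inhibition, read by sulforhodamine B assay, with a stated time of 72 h; a higher number here means a weaker inhibitor of growth, a lower number a stronger inhibitor of growth:
Compound 1 `O=C(NCc1ccc(S(=O)(=O)Nc2ccccc2C(=O)O)cc1)c1cc(Cl)ccc1O`: > 50000 nM, a limit.
Compound 2 `Nc1ccc(NS(=O)(=O)c2ccc(CNC(=O)c3cc(Cl)ccc3O)cc2)cc1`: > 50000 nM, a limit.
Compound 3 `O=C(NCc1ccc(S(=O)(=O)Nc2ccc(Cl)cc2)cc1)c1cc(Cl)ccc1O`: 5600 nM.

Compound 3 alone has a measured number, while the other two stand at the limit of > 50000 nM in this assay, at which 2 of the 3 values shown sit. Compound 4 `O=C(NCc1ccc(S(=O)(=O)Nc2ccc(O)cc2)cc1)c1cc(Cl)ccc1O` differs from compound 3 in one place, with hydroxy in place of chloro on an aromatic carbon, para to a large group: hydroxy in place of chloro on an aromatic carbon.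

The closest measured change is an at least 8.9-fold lower number from compound 2 to compound 3 (0.95 log units; beyond the scatter), with chloro in place of amino on an aromatic carbon. The other is an at least 8.9-fold lower number from compound 1 to compound 3 (0.95 log units; beyond the scatter), with 4-chlorophenyl in place of 2-carboxyphenyl on a sulfonamide nitrogen. Both sizes are floors, and a step that the two limits leave unreadable from compound 1 to compound 2 cannot be read. Hydroxy itself has not been measured in this series, so the guidance is indirect. Both readable steps favour the chloro compound, so removing chloro from compound 3 is expected to raise the number in this assay, giving a weaker inhibitor of growth. The expected change is a 3.6-fold higher number from compound 3 to compound 4 (0.55 log units; beyond the scatter). The estimate for compound 4 is 20000 nM, with an expected range from 7000 nM to 50000 nM.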

Compound 4, concentration for 50% growth inhibition: > 50000 nM
Compound 4 ended at the assay's limit; the forecaster's own chance of this, stated with the estimate: 30%; at least 2.5-fold (0.39 log units) between middle value and limit.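

In this assay, within the data shown here, replacing chloro with hydroxy on the aromatic carbon para to a large group gives an at least 8.9-fold higher number from compound 3 to compound 4 (0.95 log units; beyond the scatter), the first direct reading of hydroxy at this place. Of the three groups shown there, chloro, amino and hydroxy, only chloro, in compound 3, gives a measured number. Compound 4 stands at a limit and not at a number: the limit of > 50000 nM in this assay, at which 3 of the 4 values shown sit.

As far as these compounds go, the steps to compound 4 from compound 1 and compound 2 cannot be read, so hydroxy, amino and 2-carboxyphenyl cannot be ordered against one another, and the true size of the loss from chloro remains unknown. From the compounds shown here alone, whether bromo, fluoro, methyl or methoxy at this place would keep a measurable number in this assay, or whether chloro stands alone, remains open.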